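Ring size shifts, then a carbamate swap awaits measurement

A few compounds are considered here, and "the series" means these few. Any claim that something is new, unique, unknown or untested is made for them only; others in the source may bear on it.

Three compounds share a core and differ only in the cyclic amidine on the aromatic nitrogen. Compound 1 `O=C(N[C@@H](CCC(=O)N1CCN(c2cccc(NC3=NCCN3)c2)CC1)C(=O)O)OCc1ccccc1` gives 3 nM in a functional assay (muscle tissue) for inhibition, with Homo sapiens as the target; a lower number here means a stronger inhibitor, a higher number a weaker inhibitor. Compound 2 `O=C(N[C@@H](CCC(=O)N1CCN(c2cccc(NC3=NCCCN3)c2)CC1)C(=O)O)OCc1ccccc1` gives 1.1 nM, and compound 3 `O=C(N[C@@H](CCC(=O)N1CCN(c2cccc(NC3=NCCCCN3)c2)CC1)C(=O)O)OCc1ccccc1` gives 1.7 nM. Compound 2 carries the lowest number of the three: the step of a 2.7-fold lower number from compound 1 to compound 2 (0.44 log units; beyond the scatter) lies beyond the scatter, whereas the step of a 1.5-fold higher number from compound 2 to compound 3 (0.19 log units; within the scatter) and the step of a 1.8-fold lower number from compound 1 to compound 3 (0.25 log units; within the scatter) do not.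

Compound 4 `CC(C)COC(=O)N[C@@H](CCC(=O)N1CCN(c2cccc(NC3=NCCCN3)c2)CC1)C(=O)O` is not yet measured. It differs from compound 2 at a different place altogether: isopropyl in place of phenyl on a saturated chain carbon bound to an oxygen next to a carbonyl group, that is, benzyloxycarbonyl to isobutoxycarbonyl. For the measured compounds named here, none of the three measured steps touches this carbamate, so no measured step bears directly on it. With no guide, compound 4 is expected to stay near compound 2, with a step no larger than a 2.3-fold higher number from compound 2 to compound 4 (0.36 log units; beyond the scatter) and possibly within the scatter. Compound 4 is therefore estimated at 2.5 nM, in the range 0.6 nM to 10 nM.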

Compound 4, half-maximal inhibitory concentration: 0.91 nM
Compound 4: the middle estimate sits 2.7-fold (0.44 log units) above what was measured; the measured number falls inside the stated range.
By their numbers in this assay, from the lowest: compounds 4, 2, 3 and 1 (each within the scatter of the next, the first and the last beyond it).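

At the carbamate, the step of a 1.2-fold lower number from compound 2 to compound 4 (0.08 log units; within the scatter) shows that in this assay isobutoxycarbonyl and benzyloxycarbonyl cannot be told apart. For this pair, the phenyl is therefore not needed for a low number at this place, since the open-chain isopropyl that replaces it, with no ring, reads the same within the scatter. Nothing available explains why the two groups read alike.

As far as these compounds go, whether a longer chain, a primary amine or a carboxylic acid at the end of the chain in place of isopropyl would also read the same remains open. Isobutoxycarbonyl also appears here only with the ring of compound 2, so it is unknown whether this equivalence would hold with the ring of compound 1 or compound 3.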